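The compounds below may be only part of what the source reports. "The series", "measured", "known", "first", "only" and "open" are said of these compounds alone.

Measured in a functional assay on Caco-2 cells (Homo sapiens), read by MTT assay, with a stated time of 48 h; on this read-out lower numbers stand for stronger inhibition and higher numbers for weaker inhibition:
- compound 1 `C#CCNC(=O)c1ccc(C(CC)(CC)c2ccc(OCC(O)C(C)(C)C)c(C)c2)n1CC`: 39100 nM
- compound 2 `C=CCN(C)C(=O)c1ccc(C(CC)(CC)c2ccc(OCC(O)C(C)(C)C)c(C)c2)n1CC`: > 50000 nM (a limit of the assay, not a number)
- compound 3 `CC[C@@H](C)[C@H](NC(=O)c1ccc(C(CC)(CC)c2ccc(OCC(O)C(C)(C)C)c(C)c2)n1CC)C(=O)O`: 3400 nM

Compound 3 stands lowest of these, and both steps that reach it lie beyond the scatter: a 12-fold lower number from compound 1 to compound 3 (1.06 log units; beyond the scatter) and an at least 14-fold lower number from compound 2 to compound 3 (1.16 log units; beyond the scatter).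

The next compound is compound 4 `CCn1c(C(=O)N(C)CC(=O)O)ccc1C(CC)(CC)c1ccc(OCC(O)C(C)(C)C)c(C)c1`, which differs from compound 3 as follows: (carboxymethyl)(methyl)amino in place of (1-carboxy-2-methylbutyl)amino on a carbonyl carbon. It keeps a carboxy-bearing group, as in compound 3, but the amino group now carries a methyl, as the allyl(methyl)amino of compound 2 does. For the measured compounds named here, no measured step isolates this exchange, so the two large steps above are the only guide. They suggest that compound 4 should stay nearer compound 3 than compound 2, with some loss possible.

In this assay the expected change is a 2.4-fold higher number from compound 3 to compound 4 (0.37 log units; beyond the scatter), a moderately higher number. For compound 4 the estimated value is 8000 nM, with an expected range of 2000 nM to 32000 nM.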

Compound 4, half-maximal inhibitory concentration: 31900 nM
Estimate against measurement, compound 4: 4.0-fold (0.60 log units) below; low and high end bracket the measured number.
By their numbers in this assay, from the lowest: compound 3; then compounds 4 and 1 (each within the scatter of the next). At a limit, above all of these: compound 2.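

In this assay a carboxy group on this amide does not by itself keep the number low: a 9.4-fold higher number from compound 3 to compound 4 (0.97 log units; beyond the scatter) with (carboxymethyl)(methyl)amino in place of (1-carboxy-2-methylbutyl)amino on a carbonyl carbon. Compound 4 also gives a 1.2-fold lower number from compound 1 to compound 4 (0.09 log units; within the scatter) against a partner without a carboxy group, so across these two compounds the carboxy group brings no gain beyond the scatter. Against compound 2 the result gives an at least 1.5-fold lower number from compound 2 to compound 4 (0.19 log units; that floor lies within the scatter) and this is only a floor set by a limit of the assay: the limit of > 50000 nM in this assay, at which 1 of the 4 values shown sits.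

The step from compound 3 to compound 4 changes the side chain and adds the methyl on the nitrogen together, so the two cannot be separated here. A carboxymethylamino group with the amide hydrogen kept, or a methylated form of the 1-carboxy-2-methylbutyl chain, would separate them.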